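Formyl to cyanosulfanyl on two fused cores

The compounds below may be only part of what the source reports. "The series", "measured", "known", "first", "only" and "open" are said of these compounds alone.

Compound 1 `O=Cc1c(-c2ccc([N+](=O)[O-])cc2)nc2sc(Cc3ccc(Cl)cc3)nn12`: 13000 nM
Compound 2 `O=Cc1c(-c2cc3ccccc3oc2=O)nc2sc(Cc3ccc(Cl)cc3)nn12`: 750 nM
Compound 3 `N#CSc1c(-c2ccc([N+](=O)[O-])cc2)nc2sc(Cc3ccc(Cl)cc3)nn12`: 20000 nM

In an ADME assay on CCRF-CEM cells (Homo sapiens) for cytotoxicity, with a stated time of 72 h (on this read-out lower numbers stand for stronger inhibition and higher numbers for weaker inhibition), compound 2 gives the lowest number of the three, and its gaps to compound 1 and compound 3 lie beyond the scatter. The difference between the cores of compound 1 and compound 2 is not broken down here. From compound 1 to compound 3 the change is cyanosulfanyl in place of formyl on an aromatic carbon, and it gave a 1.5-fold higher number from compound 1 to compound 3 (0.19 log units; within the scatter). Compound 4 `N#CSc1c(-c2cc3ccccc3oc2=O)nc2sc(Cc3ccc(Cl)cc3)nn12`, not yet measured, carries the same kind of change on the core of compound 2: cyanosulfanyl in place of formyl on an aromatic carbon. The places differ only in that the ring atom next to the change bears a 4-nitrophenyl group in compound 1, while in compound 2 it is described as bearing a large group. In this assay the step from compound 2 to compound 4 is expected to be small, a 1.5-fold higher number from compound 2 to compound 4 (0.17 log units; within the scatter), because compound 1 to compound 3 showed a 1.5-fold higher number from compound 1 to compound 3 (0.19 log units; within the scatter). Compound 4 is therefore estimated at 1100 nM, between 400 nM and 3500 nM.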

Compound 4, half-maximal inhibitory concentration: 1400 nM
For compound 4 the middle estimate is 1.3-fold (0.10 log units) below the measured one; the measured number falls inside the stated range.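

In this assay, putting cyanosulfanyl in place of formyl on the core of compound 2 gave a 1.9-fold higher number from compound 2 to compound 4 (0.27 log units; within the scatter). Set beside the earlier step, the same change reads alike on both cores: the same change on two cores in this assay, a 1.5-fold higher number (0.19 log units; within the scatter) from compound 1 to compound 3 and a 1.9-fold higher number (0.27 log units; within the scatter) from compound 2 to compound 4, 1.2-fold (0.08 log units) apart, within the scatter of two such steps This shows that, for these two pairs, the change carried from one core to the other with no step beyond the scatter, but two pairs do not establish a rule for the series and say nothing about the cause.

The compounds shown leave open whether a carboxylic acid or an amine on the same aromatic carbon would give a step of similar size. On these data alone, it also remains open whether the change would read the same on a core bearing a plain phenyl group instead of the 4-nitrophenyl group.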